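The compounds below may be only part of what the source reports. "The series", "measured", "known", "first", "only" and "open" are said of these compounds alone.

Measured in a physicochemical assay for solubility; a higher number here means a more soluble compound, a lower number a less soluble compound:
- compound 1 `O=C(c1ccccc1)N1CCC(NS(=O)(=O)c2cc(S(=O)(=O)c3ccccc3)ccc2C(F)(F)F)CC1` gives 12500 nM
- compound 2 `O=C(c1ccc(Cl)nc1)N1CCC(NS(=O)(=O)c2cc(S(=O)(=O)c3ccccc3)ccc2C(F)(F)F)CC1` gives 25000 nM
- compound 3 `O=S(=O)(NC1CCN(S(=O)(=O)c2ccccc2)CC1)c1cc(S(=O)(=O)c2ccccc2)ccc1C(F)(F)F` gives 25000 nM

Compound 3 stands level with compound 2 and within the scatter of compound 1. The unmeasured compound 4 `O=C(O)c1ccc(N2CCC(NS(=O)(=O)c3cc(S(=O)(=O)c4ccccc4)ccc3C(F)(F)F)CC2)cc1` carries 4-carboxyphenyl in place of phenylsulfonyl on an amine nitrogen in a ring. Two measured steps changed this same nitrogen substituent, a 2.0-fold higher number from compound 1 to compound 3 (0.30 log units; within the scatter) and no change at the digits printed from compound 2 to compound 3 (within the scatter). A third, a 2.0-fold higher number from compound 1 to compound 2 (0.30 log units; within the scatter), changed another part of the molecule. None of them introduces 4-carboxyphenyl, so they guide the expectation only loosely. No step beyond the scatter is therefore expected in this assay, though the expectation leans slightly upward. The expected step is a 1.6-fold higher number from compound 3 to compound 4 (0.20 log units; within the scatter). Compound 4 is estimated at 40000 nM, with an expected range of 12500 nM to 100000 nM.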

Compound 4, solubility: 25000 nM
Compound 4: middle estimate off by 1.6-fold (0.20 log units), on the high side; low and high end bracket the measured number.
By their numbers in this assay, from the lowest: compounds 1, 2, 3 and 4 (each within the scatter of the next).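

In this assay putting 4-carboxyphenyl on the amine nitrogen in the ring gives no change at the digits printed from compound 3 to compound 4 (within the scatter) and no change at the digits printed from compound 2 to compound 4 (within the scatter) and a 2.0-fold higher number from compound 1 to compound 4 (0.30 log units; within the scatter) against the earlier nitrogen substituents. For the compounds shown here, this nitrogen thus carries a directly joined aryl group with a hydrogen-bond donor as well as the carbonyl and sulfonyl links of the earlier compounds, and all four numbers stay within the scatter of one another. No evidence is available that explains this result.

The compounds shown leave open whether an aliphatic amine or a longer alkyl chain on this nitrogen would move the number beyond the scatter. A plain phenyl joined directly to this nitrogen is also absent, so the carboxylic acid cannot be judged apart from its ring.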